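Swapping a Sulfonyl Group in an Inactive Pair

A few compounds are considered here, and "the series" means these few. Any claim that something is new, unique, unknown or untested is made for them only; others in the source may bear on it.

Compound 1, `CCOC(=O)[C@@H]1CCCN(S(=O)(=O)c2ccc(S(=O)(=O)N3CCOCC3)cc2)C1`: in a functional assay on MIA PaCa-2 cells (Homo sapiens) for inhibition, read by MTT assay, with a stated time of 3 days (on this read-out higher numbers stand for weaker inhibition and lower numbers for stronger inhibition), compound 1 gives > 10000 nM.
Compound 2, `CCN(CC)S(=O)(=O)c1ccc(S(=O)(=O)N2CCC[C@@H](C(=O)N(C)C(C)C)C2)cc1`: in this assay compound 2 gives > 10000 nM.

For compound 1 this value is a limit of the assay, not a measured number. The value of compound 2 is likewise only a limit. Within the data shown here, compound 1 therefore stands at the limit of > 10000 nM in this assay, at which 2 of the 2 values shown sit, together with the only other value shown, so no step between measured compounds can be drawn and nothing yet tells how any change moves potency.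

Compound 3, `CCOC(=O)[C@@H]1CCCN(S(=O)(=O)c2ccc(S(=N)(=O)N(CC)CC)cc2)C1`, differs from compound 1 in one place: a group of 8 heavy atoms (4 carbon, 2 nitrogen, 1 oxygen, 1 sulfur; no ring) in place of a group of 9 heavy atoms (4 carbon, 1 nitrogen, 3 oxygen, 1 sulfur; one six-membered non-aromatic ring with 2 hetero atoms), on an aromatic carbon. With both measured values sitting at a limit, no step beyond the usual scatter is expected in this assay for this change, in either direction. Compound 3 is therefore expected to give about 20000 nM in this assay, most likely reported again as a limit, within a range from 3000 nM to 100000 nM. The expected step that the limit leaves unreadable from compound 1 to compound 3 is essentially none.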

Compound 3, half-maximal inhibitory concentration: > 10000 nM
Compound 3 ended at the assay's limit; the forecaster's own chance of this, stated with the estimate: 80%; the middle value lies beyond the limit too.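

Compound 1 and compound 3 both give a limit of the assay rather than a measured number, so no step between them can be read: the limit of > 10000 nM in this assay, at which 3 of the 3 values shown sit.

Left open is whether the (morpholin-4-yl)sulfonyl group and the group replacing it differ at all, and which change, if any, would bring a measurable value in this assay.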